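Trading hydroxy for fluoro in a growth inhibitor

The compounds below may be only part of what the source reports. "The series", "measured", "known", "first", "only" and "open" are said of these compounds alone.

In a functional assay on HL-60 cells (Homo sapiens) for inhibition (a higher number here means a weaker inhibitor of growth, a lower number a stronger inhibitor of growth), compound 1 (`COc1ccc(-n2cnnc2-c2cc(OC)c(OC)c(OC)c2)cc1`) gives 4070 nM as its reading. Compound 2 (`COc1ccc(-n2cnnc2-c2cc(OC)c(OC)c(OC)c2)cc1O`) gives 389 nM and holds the lower of the two numbers, which makes it the stronger growth inhibitor of this pair. Hydroxy in place of hydrogen on an aromatic carbon is the only difference between them, and the result is a 10-fold lower number from compound 1 to compound 2 (1.02 log units; beyond the scatter) as a large step.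

Compound 3 (`COc1ccc(-n2cnnc2-c2cc(OC)c(OC)c(OC)c2)cc1F`) has fluoro in place of hydroxy on an aromatic carbon, ortho to a methoxy group (fluoro in place of hydroxy on an aromatic carbon). Going by the values given here, only that one measured step bears on this swap. Among the compounds with values here, compound 3 loses the hydroxy that separates compound 2 from compound 1, and no fluoro compound has been measured yet to show how fluoro compares with hydrogen here. Part of a 10-fold lower number from compound 1 to compound 2 (1.02 log units; beyond the scatter) may therefore be given back, so a higher number is expected in this assay by a step smaller than that one. Compound 3 is estimated at 1300 nM with 250 nM to 6000 nM as the expected range. That estimate means a 3.3-fold higher number from compound 2 to compound 3 (0.52 log units; beyond the scatter) as the expected step.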

Compound 3, concentration for 50% growth inhibition: 6030 nM
The estimate for compound 3 lay 4.6-fold (0.67 log units) below the measured number; measured number above the stated range.
By their numbers in this assay, from the lowest: compound 2; then compounds 1 and 3 (each within the scatter of the next).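

In this assay, fluoro in place of hydroxy on this aromatic carbon gives a 16-fold higher number from compound 2 to compound 3 (1.19 log units; beyond the scatter), so the gain seen with hydroxy does not carry over to fluoro, even though each group has 1 heavy atom. Fluoro in place of hydrogen on the same carbon gives a 1.5-fold higher number from compound 1 to compound 3 (0.17 log units; within the scatter), which leaves compounds 1 and 3 within the usual scatter of each other, and among these three compounds only compound 2, the one with hydroxy, stands apart. Nothing here gives a measured reason for the effect of hydroxy on growth inhibition.

Hydroxy brings 1 hydrogen-bond donor and 1 hydrogen-bond acceptor where fluoro brings neither, but these compounds cannot show whether either count is what matters, and an amine or a methoxy on this carbon would give a further comparison. As far as these compounds go, it also remains open whether hydroxy would have a similar effect on another aromatic carbon of the shared core, or whether this pattern would hold in any other assay.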